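A few compounds are considered here, and "the series" means these few. Any claim that something is new, unique, unknown or untested is made for them only; others in the source may bear on it.

Measured compounds:
- compound 1 `C[C@@H](O)[C@H](NC(=O)CN(c1ncnc2c1ncn2C1CCCCO1)C1CC1)C(=O)OCc1ccccc1`: 23.4%
- compound 2 `O=C(CN(c1ncnc2c1ncn2C1CCCCO1)C1CC1)N[C@@H](CC(=O)OCc1ccccc1)C(=O)OCc1ccccc1`: 25.1%

In a functional assay on the whole organism (Tail, strain ICR) with Mus musculus as the target, in the tail flick test, with a stated time of 90 min, at a dose of 25 umol/kg by the oral route (on this read-out higher numbers stand for a stronger effect at the one dose given and lower numbers for a weaker effect), compound 1 gives 23.4% and compound 2 gives 25.1%; the two numbers sit within the scatter of each other, so compound 2 cannot be set apart from compound 1 on this read-out. Within the data shown here, the single measured step, a number 1.7 percentage points higher from compound 1 to compound 2 (within the scatter), exchanges the side chain on the saturated chain carbon bound to an amide-type nitrogen and a carbonyl carbon and leaves the read-out essentially unchanged.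

Compound 3 `CC(C)(C)OC(=O)NCCCC[C@H](NC(=O)CN(c1ncnc2c1ncn2C1CCCCO1)C1CC1)C(=O)OCc1ccccc1` is not yet measured. Its difference from compound 2 is 3-((tert-butoxycarbonyl)amino)propyl in place of benzyloxycarbonyl on a saturated chain carbon, two bonds along the chain from an amide-type nitrogen and a carbonyl carbon. This again alters the side chain at the same region of the molecule that the step from compound 1 to compound 2 touched, and that step stayed within the scatter. Among the measured compounds shown here, no measured step shows the side chain moving this assay, so no change beyond the scatter is expected: the estimated step is a number 1.1 percentage points lower from compound 2 to compound 3 (within the scatter). For compound 3 the expected value in this assay is 24%, with a range from 10% to 40%.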

Compound 3, a percentage reported as activity, at one dose (the size of the read-out at that dose, not a potency): 32.9%
Estimate against measurement, compound 3: 8.9 percentage points below; low and high end bracket the measured number.
By their numbers in this assay, from the lowest: compounds 1, 2 and 3 (each within the scatter of the next).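

In this assay, 3-((tert-butoxycarbonyl)amino)propyl in place of benzyloxycarbonyl gives a number 7.8 percentage points higher from compound 2 to compound 3 (within the scatter), so this side chain, the first in the series to carry nitrogen, is not set apart from the (benzyloxycarbonyl)methyl side chain. Against the 1-hydroxyethyl side chain, the 4-((tert-butoxycarbonyl)amino)butyl side chain gives a number 9.5 percentage points higher from compound 1 to compound 3 (within the scatter), so three side chains that differ in size and atoms all remain within the scatter at this saturated chain carbon. Nothing given here bears on the origin of these small differences.

Going by these compounds, it remains open whether a free amine at the end of the butyl chain, or a carboxylic acid in place of the benzyloxycarbonyl group, would move the read-out beyond the scatter. The series also leaves open whether any side chain at this position separates from the others at another dose or time.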